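Dimethoxyphenyl in place of fluorophenyl on the shared core

A few compounds are considered here, and "the series" means these few. Any claim that something is new, unique, unknown or untested is made for them only; others in the source may bear on it.

Compound 1 `O=C(O)Cc1sc(CSc2ccccc2)nc1-c1ccc(Cl)cc1`: in an in vitro assay on HEK385-7 cells for displacement of a labelled ligand from prostaglandin D2 receptor 2 (Homo sapiens) (a lower number here means a stronger inhibitor, a higher number a weaker inhibitor), compound 1 gives 250 nM
Compound 2 `O=C(O)Cc1sc(C(c2ccccc2)c2ccc(Cl)cc2)nc1-c1ccc(Cl)cc1`: in this assay compound 2 gives 45 nM
Compound 3 `O=C(O)Cc1sc(C(c2ccccc2)c2ccccc2)nc1-c1ccc(F)cc1`: in this assay compound 3 gives 8.7 nM

Among these three, compound 3 has the lowest number. Compound 2 stands nearest to it, and the gap between them lies beyond the scatter; compound 1 stands furthest away, again beyond the scatter. Within the data shown here, no pair of these three differs in only one place, so no single change can be read off from them.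

Compound 4 `COc1ccc(OC)c(-c2nc(C(c3ccccc3)c3ccccc3)sc2CC(=O)O)c1` differs from compound 3 in one place: 2,5-dimethoxyphenyl in place of 4-fluorophenyl on an aromatic carbon. Nothing measured here speaks to the effect of such a change on the shared core. A modest weakening is expected, with a real chance that the step stays within the scatter, so the step from compound 3 to compound 4 is estimated at a 2.9-fold higher number from compound 3 to compound 4 (0.46 log units; beyond the scatter). On this basis compound 4 is expected to give 25 nM, with a range from 5 nM to 120 nM.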

Compound 4, half-maximal inhibitory concentration: > 105 nM
Compound 4 gave a limit, no number (the forecaster's own chance of this, stated with the estimate: 2%); middle value at least 4.2-fold (0.62 log units) away from the limit.
By their numbers in this assay, from the lowest: compound 3; then compound 2; then compound 1.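

Among these compounds, this is the first single change that can be read on the shared core, and in this assay it is large: putting 2,5-dimethoxyphenyl in place of 4-fluorophenyl, on the aromatic carbon next to the ring nitrogen, gives an at least 12-fold higher number from compound 3 to compound 4 (1.08 log units; beyond the scatter). Compound 4 gives > 105 nM, which is a limit of the assay and not a number: the limit of > 105 nM in this assay, at which 1 of the 4 values shown sits. From the compounds shown here alone, the position is therefore not indifferent to the group it carries, though the full size of the step remains unknown.

Going by these compounds, whether a single methoxy group or a hydroxyl group on that phenyl ring would bring the same loss stays open. Also open, on these data alone, is whether an unsubstituted phenyl at this place would stand nearer to compound 3 or to compound 4.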